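This account rests on a few compounds, and the source may have more. Where it says the series, first, only, none or still open, it means among the compounds named here.

In a functional assay on A-375 cells (Homo sapiens) for cytotoxicity, read by MTT assay, with a stated time of 72 h, tested at 30 uM (a higher number here means more inhibition of growth at the concentration tested, a lower number less inhibition of growth), three compounds have been measured so far:

Compound 1 `Cc1ccnc(/C(N)=N/NC(=S)N2CCSCC2)c1`: 84.9%
Compound 2 `Cc1cccc(/C(N)=N/NC(=S)N2CCCCC2)n1`: 80.9%
Compound 3 `Cc1ccnc(/C(N)=N/NC(=S)N2CCN(c3ccccn3)CC2)c1`: 79.4%

Compound 2 stands second highest of the three numbers. Its nearest neighbour is compound 3, whose value lies within the scatter of it, and its furthest is compound 1, whose value also lies within the scatter, so the three cannot be told apart in this assay.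

Compound 4 `Cc1cccc(/C(N)=N/NC(=S)N2CCOCC2)n1` has not yet been measured. It differs from compound 2 in one place: morpholin-4-yl in place of piperidin-1-yl on a thiocarbonyl carbon. For the measured compounds named here, no step between measured compounds is known, and since compound 1 and compound 3 both sit within the scatter of compound 2, no step beyond the scatter is expected in either direction. Compound 4 is expected to give 79% in this assay, with a range from 66% to 90%. The expected step is a number 1.9 percentage points lower from compound 2 to compound 4 (within the scatter), within the scatter.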

Compound 4, percent growth inhibition at one concentration: 74.3%
Compound 4: middle estimate off by 4.7 percentage points, on the high side; the measured number falls inside the stated range.
By their numbers in this assay, from the lowest: compounds 4, 3, 2 and 1 (each within the scatter of the next, the first and the last beyond it).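

Morpholin-4-yl in place of piperidin-1-yl on a thiocarbonyl carbon gives the first step that can be read at this position, and in this assay it is a number 6.6 percentage points lower from compound 2 to compound 4 (within the scatter). The number therefore stays within the scatter when the ring gains a second hetero atom and a hydrogen-bond acceptor. No measurement is available that would explain this step.

From the compounds shown here alone, whether an open-chain dimethylamino group on the same thiocarbonyl carbon would give a step beyond the scatter remains open.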